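Bromo to iodo on the 3-substituted phenyl

This account rests on a few compounds, and the source may have more. Where it says the series, first, only, none or still open, it means among the compounds named here.

Values in a functional assay on SK-MEL-28 cells (Homo sapiens) for cytotoxicity, read by CCK-8 assay, with a stated time of 24 h; on this read-out lower numbers stand for stronger inhibition and higher numbers for weaker inhibition:
- compound 1 `COc1ccccc1Oc1c(N)nc(Cc2ccccc2)nc1OCCO`: 14000 nM
- compound 2 `COc1ccccc1Oc1c(N)nc(-c2cccc(C)c2)nc1OCCO`: 14700 nM
- compound 3 `COc1ccccc1Oc1c(N)nc(-c2cccc(Br)c2)nc1OCCO`: 4040 nM

Compound 3 holds the lowest of the three numbers, and both of the other compounds lie beyond the scatter from it. The next compound to be tested is compound 4 `COc1ccccc1Oc1c(N)nc(-c2cccc(I)c2)nc1OCCO`. The change is iodo in place of bromo on an aromatic carbon, with iodo in place of bromo on an aromatic carbon, meta to a large group.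

For the measured compounds named here, no measured step exchanges one halogen for another, so the data give no direct measure of this change. The closest evidence is the swap at the same place, a 3.6-fold lower number from compound 2 to compound 3 (0.56 log units; beyond the scatter). The two exchanges of benzyl bear on it less directly, and they differ: a 1.1-fold higher number from compound 1 to compound 2 (0.02 log units; within the scatter) stays within the scatter, whereas a 3.5-fold lower number from compound 1 to compound 3 (0.54 log units; beyond the scatter) goes beyond it. Going by the values given here, with only one bromo compound measured, the swap to iodo is expected to give a smaller step than the methyl to bromo one, in the same direction if it shows at all. The estimated step is a 1.3-fold lower number from compound 3 to compound 4 (0.13 log units; within the scatter), which is expected to stay within the scatter in this assay. For compound 4 the estimated value is 3000 nM, with an expected range of 1300 nM to 7000 nM.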

Compound 4, half-maximal inhibitory concentration: 11200 nM
The estimate for compound 4 lay 3.7-fold (0.57 log units) below the measured number; measured number outside the range, above it.
By their numbers in this assay, from the lowest: compound 3; then compounds 4, 1 and 2 (each within the scatter of the next).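

In this assay this place on the phenyl ring proves sensitive to which halogen it carries: the exchange of bromo for iodo gives a 2.8-fold higher number from compound 3 to compound 4 (0.44 log units; beyond the scatter) and so does not extend the low number of the 3-bromophenyl compound to its 3-iodophenyl counterpart. Iodo instead sits with the methyl and benzyl compounds, as a 1.3-fold lower number from compound 2 to compound 4 (0.12 log units; within the scatter) and a 1.3-fold lower number from compound 1 to compound 4 (0.10 log units; within the scatter) both stay within the scatter, which leaves compound 3 alone with the lowest number in the set and beyond the scatter from each of the other three compounds. Nothing shown here gives a measured reason for the gap between bromo and iodo.

With a single bromo compound and a single iodo compound, the series cannot yet show whether the low number of compound 3 is particular to bromo or part of a wider trend among substituents at this place. Chloro and fluoro would test this within the halogens, while trifluoromethyl, methoxy, nitrile, an amine or a carboxylic acid on the same carbon would show how far the result extends beyond them.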